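This account rests on a few compounds, and the source may have more. Where it says the series, first, only, none or still open, it means among the compounds named here.

The measured compounds are:

Compound 1 `CS(=O)(=O)c1ccc(F)c(C#Cc2cc(Cl)ccc2OCC(=O)O)c1`, which in an assay on CHO cells for displacement of a labelled ligand from prostaglandin D2 receptor 2 (Homo sapiens), read by scintillation counting (a lower number here means a stronger inhibitor, a higher number a weaker inhibitor), gives 3.3 nM.
Compound 2 `CN(C)S(=O)(=O)c1cccc(C#Cc2cc(Cl)ccc2OCC(=O)O)c1`, which in this assay gives 14 nM.
Compound 3 `Cc1ccc(S(=O)(=O)N(C)C)cc1C#Cc1cc(Cl)ccc1OCC(=O)O`, which in this assay gives 5 nM.

Compound 3 stands second highest of these three numbers. Going by the values given here, compound 1 lies within the scatter of it, so the two cannot be ranked against each other; compound 2 is the furthest away, and the one measured step, a 2.8-fold lower number from compound 2 to compound 3 (0.45 log units; beyond the scatter), is a modest one beyond the scatter.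

Compound 4 `CN(C)S(=O)(=O)c1ccc(F)c(C#Cc2cc(Cl)ccc2OCC(=O)O)c1` is not yet measured. It differs from compound 3 in one place: fluoro in place of methyl on an aromatic carbon. Among the compounds with values here, the only measured step that touches this same aromatic carbon is a 2.8-fold lower number from compound 2 to compound 3 (0.45 log units; beyond the scatter), where a methyl enters in place of hydrogen. Within the data shown here, no measured step compares fluoro with methyl directly. Compound 1 also carries a fluoro at this kind of position and gives 3.3 nM, a low number, but its sulfonyl part differs, so it offers only a hint.

Taken together, no step beyond the scatter is expected in this assay for this exchange. Compound 4 is therefore estimated at 5.5 nM, with a range from 2.2 nM to 14 nM, which corresponds to an expected 1.1-fold higher number from compound 3 to compound 4 (0.04 log units; within the scatter).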

Compound 4, inhibition constant: 3.1 nM
Compound 4: the middle estimate sits 1.8-fold (0.25 log units) above what was measured, and the stated range covers the measured number.
By their numbers in this assay, from the lowest: compounds 4, 1 and 3 (each within the scatter of the next); then compound 2.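

At this aromatic carbon, fluoro and methyl cannot be told apart in this assay: the exchange gives a 1.6-fold lower number from compound 3 to compound 4 (0.21 log units; within the scatter) and stays within the scatter, so this pair shows no preference for either group. Measured against hydrogen, fluoro gives a 4.5-fold lower number from compound 2 to compound 4 (0.65 log units; beyond the scatter) and goes beyond the scatter, as methyl does with a 2.8-fold lower number from compound 2 to compound 3 (0.45 log units; beyond the scatter); the lower number with a group on this carbon is therefore not tied to methyl alone, although this rests on only these two groups in one series. On the sulfonyl sulfur, the change gives a 1.1-fold lower number from compound 1 to compound 4 (0.03 log units; within the scatter) and also stays within the scatter, so with fluoro on the ring, dimethylamino and methyl at that site cannot be separated.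

Nothing given here accounts for these numbers. On these data alone, it remains open whether a methoxy, a trifluoromethyl or an amine on this same carbon would also give a lower number than hydrogen, and whether a longer chain on the sulfonyl sulfur would stay as close to methyl and dimethylamino as those two stay to each other.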